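The compounds below may be only part of what the source reports. "The series", "measured", "known", "first", "only" and "open" are said of these compounds alone.

Measured so far:
compound 1, `Cc1ccc(S(=O)(=O)Nc2ccc3c(c2)C(=O)N(C)C3=O)cc1`: > 200000 nM
compound 2, `Cc1ccc(S(=O)(=O)Nc2ccc3c(c2)C(=O)N(CCNc2ccccc2)C3=O)cc1`: 99600 nM

In an assay on isolated protein for inhibition of lysosomal alpha-glucosidase (Rattus norvegicus), read by colorimetric assay (a lower number here means a stronger inhibitor, a higher number a weaker inhibitor), compound 1 gives > 200000 nM, which is a limit of the assay and not a number. Compound 2 gives 99600 nM. The step of an at least 2.0-fold lower number from compound 1 to compound 2 (0.30 log units; that floor lies within the scatter) therefore rests on a limit at one end; only its floor is known, and that floor lies within the scatter.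

Compound 3, `Cc1ccc(S(=O)(=O)Nc2ccc3c(c2)C(=O)N(CCOc2cccc(O)c2)C3=O)cc1`, is not yet measured in this assay. It differs from compound 1 by (3-hydroxyphenoxy)methyl in place of hydrogen on a saturated chain carbon bound to an amide-type nitrogen in a ring. Within the data shown here, the one measured step that bears on this change is an at least 2.0-fold lower number from compound 1 to compound 2 (0.30 log units; that floor lies within the scatter), where a chain of comparable length on the same saturated chain carbon bound to an amide-type nitrogen in a ring brought the number off the limit to a measurable value. Because of the limit of > 200000 nM in this assay, at which 1 of the 2 values shown sits, compound 1 gives no fixed starting number, so the expectation for compound 3 is anchored on compound 2 rather than on a step size. The expected step is an at least 1.6-fold lower number from compound 1 to compound 3 (0.22 log units; that floor lies within the scatter), meaning only that the limit is expected to be left. Compound 3 is estimated at 120000 nM, with a range from 50000 nM to 300000 nM.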

Compound 3, half-maximal inhibitory concentration: 55600 nM
For compound 3 the middle estimate is 2.2-fold (0.33 log units) above the measured one, within the range that was stated.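

In this assay the change of methyl to 2-(3-hydroxyphenoxy)ethyl gives an at least 3.5-fold lower number from compound 1 to compound 3 (0.55 log units; beyond the scatter) and so, unlike the earlier step at this position, has a floor that clears the scatter, which makes this the first firm sign that a substituted chain on this saturated carbon bound to the amide-type nitrogen lowers the number on the shared core. As far as these compounds go, only a floor can be given for that step, and its true size stays unknown, because compound 1 supplies no fixed starting number: the limit of > 200000 nM in this assay, at which 1 of the 3 values shown sits. Placing 3-hydroxyphenoxy where anilino stood gives a 1.8-fold lower number from compound 2 to compound 3 (0.25 log units; within the scatter) and stays within the scatter, so this assay does not separate these two chain ends.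

Each measured chain carries an aromatic ring. The measured compounds do not show how the number would read with the ring, the hydroxy group or the chain taken alone. Also open, from the compounds shown here alone, is whether a plain phenoxy end, a carboxylic acid in place of the hydroxy group, or a longer chain such as 3-phenoxypropyl would move the number beyond the scatter from compound 3.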